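From a trifluoromethyl to a dimethoxy aniline

This account rests on a few compounds, and the source may have more. Where it says the series, first, only, none or still open, it means among the compounds named here.

- compound 1 `COc1ccc(Nc2ncc(C(F)(F)F)c(N3Cc4cccc(N(C)S(C)(=O)=O)c4C3)n2)cc1C(F)(F)F`: > 30000 nM (a limit)
- compound 2 `COc1ccc(C(F)(F)F)cc1Nc1ncc(C(F)(F)F)c(N2Cc3cccc(N(C)S(C)(=O)=O)c3C2)n1`: > 30000 nM (a limit)
- compound 3 `CN(c1cccc2c1CN(c1nc(Nc3ccc(C(F)(F)F)cc3)ncc1C(F)(F)F)C2)S(C)(=O)=O`: > 30000 nM (a limit)

In a functional assay on OVCAR-3 cells (Homo sapiens) for antiproliferative activity, read by spectrophotometry, with a stated time of 2 days (a higher number here means a weaker inhibitor of growth, a lower number a stronger inhibitor of growth), compound 3 gives > 30000 nM, which is a limit and not a number. The other two compounds give no number either: the limit of > 30000 nM in this assay, at which 3 of the 3 values shown sit.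

Compound 4 `COc1cc(Nc2ncc(C(F)(F)F)c(N3Cc4cccc(N(C)S(C)(=O)=O)c4C3)n2)cc(OC)c1` keeps the shared core and changes one group on a nitrogen on an aromatic ring: 3,5-dimethoxyphenyl in place of 4-(trifluoromethyl)phenyl on a nitrogen on an aromatic ring.

The closest evidence comes from changes to this same group: a step that the two limits leave unreadable from compound 1 to compound 2, a step that the two limits leave unreadable from compound 1 to compound 3 and a step that the two limits leave unreadable from compound 2 to compound 3. None of these has a readable size, so no step beyond the usual scatter is expected in this assay, and compound 4 will probably also return a limit.

The expected change is a number no higher from compound 3 to compound 4 (the limit leaves the size open).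

For compound 4 the estimate is 30000 nM, with an expected range from 8000 nM to 60000 nM.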

Compound 4, concentration for 50% growth inhibition: 630 nM
For compound 4 the middle estimate is 48-fold (1.68 log units) above the measured one; the whole stated range lies above it.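

In this assay, among the compounds shown here, the group at this position can decide whether growth inhibition is seen at all, something the earlier steps, none of which can be read, could not show. The change to 3,5-dimethoxyphenyl gives an at least 47-fold lower number from compound 3 to compound 4 (1.67 log units; beyond the scatter), an at least 47-fold lower number from compound 2 to compound 4 (1.67 log units; beyond the scatter) and an at least 47-fold lower number from compound 1 to compound 4 (1.67 log units; beyond the scatter). All the compounds with a trifluoromethyl on this ring stay at a limit: the limit of > 30000 nM in this assay, at which 3 of the 4 values shown sit.

Open, going by these compounds, is whether the gain comes from losing trifluoromethyl, from gaining methoxy, or from both. Also open, on these data alone, is how a single methoxy, a hydroxyl or an amine on this ring would behave.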